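A methoxy in place of methyl on the shared core

A few compounds are considered here, and "the series" means these few. Any claim that something is new, unique, unknown or untested is made for them only; others in the source may bear on it.

Compound 1 `Cc1ccc(-c2nnc(NC(=O)/C=C/c3ccc(C(F)(F)F)cc3)s2)cc1` gives 1.61 ug/mL in a functional assay on A549 cells (Homo sapiens) for antiproliferative activity, read by MTT assay, with a stated time of 48 h (a lower number here means a stronger inhibitor, a higher number a weaker inhibitor), the higher of the two numbers at hand. Compound 2 `Cc1ccc(-c2nnc(NC(=O)/C=C/c3ccc(F)cc3)s2)cc1` gives 1.23 ug/mL in this assay; the step of a 1.3-fold lower number from compound 1 to compound 2 (0.12 log units; within the scatter) concerns fluoro in place of trifluoromethyl and says nothing about the change now considered. Compound 3 `COc1ccc(-c2nnc(NC(=O)/C=C/c3ccc(C(F)(F)F)cc3)s2)cc1` differs from compound 1 by methoxy in place of methyl on an aromatic carbon. Going by the values given here, no measured step covers methoxy in place of methyl, so the expectation rests on compound 1 alone, and the step of a 1.0-fold lower number from compound 1 to compound 3 (0.00 log units; within the scatter) is expected to stay within the scatter. Compound 3 is therefore estimated at 1.6 ug/mL, within 0.7 ug/mL to 3.6 ug/mL.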

Compound 3, half-maximal inhibitory concentration: 0.69 ug/mL
Beside the measured number, compound 3's estimate is 2.3-fold (0.37 log units) above it; the measured number lies below the stated range.
By their numbers in this assay, from the lowest: compounds 3, 2 and 1 (each within the scatter of the next, the first and the last beyond it).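

The change from 4-methylphenyl to 4-methoxyphenyl gives a 2.3-fold lower number from compound 1 to compound 3 (0.37 log units; beyond the scatter) in this assay, so a group on this aromatic carbon, para to a large group, can shift the number measurably. The exchange of trifluoromethyl for fluoro, by contrast, stayed within the scatter. Nothing measured here accounts for the step.

The compounds shown leave open whether an ethoxy, a hydroxy or an amine on this carbon would give a similar number. They also leave open whether methoxy gives the same step when fluoro replaces trifluoromethyl.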